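Trading one nitrogen ring for another on compound 1

This account rests on a few compounds, and the source may have more. Where it says the series, first, only, none or still open, it means among the compounds named here.

compound 1, `O=C1NC(COCc2cc(C(F)(F)F)cc(C(F)(F)F)c2)(c2ccc(F)cc2)CN1CCN1CCCC1`: 1.6 nM
compound 2, `O=C1NC[C@@](COCc2cc(C(F)(F)F)cc(C(F)(F)F)c2)(c2ccc(F)cc2)N1`: 2.7 nM
compound 3, `O=C1NC[C@@](COCc2cc(C(F)(F)F)cc(C(F)(F)F)c2)(c2ccccc2)N1`: 6 nM

In an assay on CHO cells for displacement of a labelled ligand from Substance-P receptor (Homo sapiens) (on this read-out lower numbers stand for stronger inhibition and higher numbers for weaker inhibition), compound 1 has the lowest of the three numbers; compound 2 lies within the scatter of it, and compound 3 lies beyond it. Going by the values given here, the single measured step, a 2.2-fold higher number from compound 2 to compound 3 (0.35 log units; beyond the scatter), concerns the aromatic fluorine and not the ring nitrogen substituent, so it does not bear on the change at hand. Compound 4, `CN1CCC(N2CC(COCc3cc(C(F)(F)F)cc(C(F)(F)F)c3)(c3ccc(F)cc3)NC2=O)CC1`, differs from compound 1 by 1-methylpiperidin-4-yl in place of 2-(pyrrolidin-1-yl)ethyl on an amide-type nitrogen in a ring. Among the compounds with values here, no measured pair probes that position, so no direction can be drawn from the data, and a step of a 1.6-fold higher number from compound 1 to compound 4 (0.19 log units; within the scatter) is expected, within the scatter. Compound 4 is therefore estimated at 2.5 nM, with a range from 0.8 nM to 8 nM.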

Compound 4, inhibition constant: 0.4 nM
Compound 4: the middle estimate sits 6.3-fold (0.80 log units) above what was measured, and the stated range ends above it.
By their numbers in this assay, from the lowest: compound 4; then compounds 1 and 2 (each within the scatter of the next); then compound 3.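

In this assay, the group on the amide-type nitrogen in a ring proves able to move the number: 1-methylpiperidin-4-yl in place of 2-(pyrrolidin-1-yl)ethyl gives a 4.0-fold lower number from compound 1 to compound 4 (0.60 log units; beyond the scatter). The two groups have the same atoms, joined differently, so rearranging them alone is enough for a step beyond the scatter. Nothing at hand explains this step.

Still open, on these data alone, is whether the six-membered ring or the changed attachment accounts for the step: 2-(piperidin-1-yl)ethyl at this position would separate the two. As far as these compounds go, whether the methyl on the piperidine contributes remains open too, a question for piperidin-4-yl.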